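Shifting the Aromatic Amide Group in an Arylpiperazine Series

The compounds below may be only part of what the source reports. "The series", "measured", "known", "first", "only" and "open" are said of these compounds alone.

Three compounds sharing a methoxyphenylpiperazine linked through a propyl chain to an amide have been tested in an assay on isolated protein (spleen, strain Sprague-Dawley) for antagonist activity at Alpha-1B adrenergic receptor (Rattus norvegicus), with a stated time of 20 min; on this read-out higher numbers stand for weaker binding and lower numbers for tighter binding. Compound 1 `COc1ccccc1N1CCN(CCCNC(=O)c2ccc3[nH]ccc3c2)CC1` gives 123 nM in this assay. Compound 2 `COc1ccccc1N1CCN(CCCNC(=O)CCCc2c[nH]c3ccccc23)CC1` gives 95.5 nM, a number so close to that of compound 1 that the two cannot be told apart by repeated measurement. Compound 3 `COc1ccc2[nH]c(C(=O)NCCCN3CCN(c4ccccc4OC)CC3)cc2c1` gives 1450 nM, clearly weaker than compound 1. Compound 1 thus stands second highest of the three numbers, close to compound 2 and far from compound 3.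

Compound 4 `COc1ccccc1N1CCN(CCCNC(=O)c2cn(C)c3ccccc23)CC1` has not been measured. It differs from compound 1 in one place: 1-methyl-1H-indol-3-yl in place of 1H-indol-5-yl on a carbonyl carbon. The aromatic group on the carbonyl carbon is therefore attached through a different ring position and carries a methyl on its nitrogen in place of a hydrogen.

The measured compounds show that changing the group on the carbonyl carbon can leave the number almost unchanged, as with compound 2, or raise it considerably, as with compound 3. Within the data shown here, no directly comparable pair exists for this change. The step is expected to be a 1.5-fold higher number from compound 1 to compound 4 (0.17 log units; within the scatter), toward a somewhat higher number, but likely within the scatter. Compound 4 is expected to give 180 nM, with a range from 50 nM to 700 nM.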

Compound 4, dissociation constant: 166 nM
For compound 4 the middle estimate is 1.1-fold (0.04 log units) above the measured one; the range from low to high includes it.
By their numbers in this assay, from the lowest: compounds 2, 1 and 4 (each within the scatter of the next); then compound 3.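

Among these compounds, on this assay, putting 1-methyl-1H-indol-3-yl in place of 1H-indol-5-yl on the carbonyl carbon gives a 1.3-fold higher number from compound 1 to compound 4 (0.13 log units; within the scatter), the first step here between two measured compounds that differ in one place. This single swap alters both the ring position through which the aromatic group is attached and the nitrogen substituent, and the entering group has 0 hydrogen-bond donors where the leaving group has 1, yet the two compounds cannot be told apart, so for this pair the hydrogen-bond donor on the leaving group is not needed to keep the number within the scatter. The data offer no measured explanation for this result.

The step joins two alterations, so it cannot say whether the new attachment and the methyl would each leave the number unchanged on their own or whether their separate effects happen to offset each other; a compound with 1H-indol-3-yl on the carbonyl carbon would separate the two. Also open, as far as these compounds go, is how a larger group on the indole nitrogen, such as benzyl, would read on this assay.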